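The source may report more compounds than this note shows. Statements on the series, on what has been measured and on what is new or still open speak of the compounds shown alone.

Two hydrazones built on the same core have been measured in a functional assay, read by spectrophotometry, with a stated time of 1 h; a higher number here means a weaker inhibitor, a lower number a stronger inhibitor. Compound 1 `O=c1cc(/C=N\Nc2ccc([N+](=O)[O-])cc2[N+](=O)[O-])c2ccc(OCc3ccccc3)cc2o1` gives 1970000 nM, while compound 2 `O=c1cc(/C=N\Nc2ccccc2)c2c(OCc3ccccc3)cc(OCc3ccccc3)cc2o1` gives 401000 nM; compound 2 thus holds the lower of the two numbers, the only other one, compound 1, standing beyond the scatter above it. Compound 3 `O=c1cc(/C=N\Nc2ccc([N+](=O)[O-])cc2[N+](=O)[O-])c2c(OCc3ccccc3)cc(OCc3ccccc3)cc2o1` keeps the core of compound 2 but carries 2,4-dinitrophenyl in place of phenyl on an amine nitrogen. Within the data shown here, no measured pair isolates this change, so the expected step of a 2.0-fold higher number from compound 2 to compound 3 (0.30 log units; within the scatter) is a weakening in this assay of moderate size, uncertain because compound 1 differs in more than one place. Compound 3 is expected to give 800000 nM, in the range 250000 nM to 2500000 nM.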

Compound 3, half-maximal inhibitory concentration: 734000 nM
Compound 3: the middle estimate sits 1.1-fold (0.04 log units) above what was measured, within the range that was stated.
By their numbers in this assay, from the lowest: compounds 2 and 3 (each within the scatter of the next); then compound 1.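

Replacing phenyl with 2,4-dinitrophenyl on an amine nitrogen gives in this assay a 1.8-fold higher number from compound 2 to compound 3 (0.26 log units; within the scatter), so this swap does not separate the two compounds, even though the group entering has more heavy atoms than the one leaving. Benzyloxy in place of hydrogen on an aromatic carbon gives a 2.7-fold lower number from compound 1 to compound 3 (0.43 log units; beyond the scatter), a modest step seen here with the 2,4-dinitrophenyl group in place. No available evidence explains either step.

Open, as far as these compounds go, is whether an amine or a carboxylic acid on that nitrogen-bound phenyl would change the number. Also open, from the compounds shown here alone, is whether a methoxy group could replace benzyloxy and give a similar step.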